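Swapping furan-2-yl for 4-methylthiophen-2-yl

This account rests on a few compounds, and the source may have more. Where it says the series, first, only, none or still open, it means among the compounds named here.

- compound 1 `Cc1cnc(Nc2ccc(C#N)cc2)nc1Nc1c(F)cc(-c2cccnc2)cc1F`: 1100 nM
- compound 2 `Cc1cc(-c2ccco2)cc(C)c1Nc1ccnc(Nc2ccc(C#N)cc2)n1`: 1700 nM

In a toxicity assay on MT4 cells (Homo sapiens) for cytotoxicity, read by MTT assay, with a stated time of 5 days (a lower number here means that less compound is tolerated, a higher number that more compound is tolerated), compound 2, at 1700 nM, lies within the usual scatter of compound 1, at 1100 nM, so the two cannot be told apart. Compound 3 `Cc1csc(-c2cc(C)c(Nc3ccnc(Nc4ccc(C#N)cc4)n3)c(C)c2)c1` differs from compound 2 by 4-methylthiophen-2-yl in place of furan-2-yl on an aromatic carbon. Among the measured compounds shown here, no measured pair shows this change on its own, and none of the compounds measured so far carries this group. No step beyond the scatter is therefore expected in this assay, and the expected step is a 1.2-fold higher number from compound 2 to compound 3 (0.07 log units; within the scatter). Compound 3 is estimated at 2000 nM, with an expected range of 700 nM to 6000 nM.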

Compound 3, half-maximal cytotoxic concentration: 34000 nM
Compound 3: middle estimate off by 17-fold (1.23 log units), on the low side; measured number above the stated range.
By their numbers in this assay, from the lowest: compounds 1 and 2 (each within the scatter of the next); then compound 3.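

This position is not neutral to the change: in this assay, 4-methylthiophen-2-yl in place of furan-2-yl gives a 20-fold higher number from compound 2 to compound 3 (1.30 log units; beyond the scatter) and is the first step beyond the scatter among these compounds. Compound 3 thus stands apart from compounds 1 and 2 as the most tolerated of the three. Nothing measured here explains this step. As far as these compounds go, it remains open whether the step belongs to the sulfur-containing ring or to its methyl group, which unsubstituted thiophen-2-yl would separate. From the compounds shown here alone, how an amine or a carboxylic acid would read on this aromatic carbon also remains open.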